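Swapping Ethoxy for Bromo: Expected Lipophilicity Shift

The source may report more compounds than this note shows. Statements on the series, on what has been measured and on what is new or still open speak of the compounds shown alone.

Three compounds have been run in a physicochemical assay for lipophilicity (a lower number here means a more polar compound, a higher number a more lipophilic compound), so far:

- compound 1 `CCOc1ccccc1C1=NC(c2ccccc2)CO1` gives 4.22
- compound 2 `Cc1cccc(C2=NC(c3ccccc3)CO2)c1` gives 4.11
- compound 3 `Cc1ccc(C2=NC(c3ccccc3)CO2)cc1` gives 4.11

Compound 1 has the highest of the three numbers, yet its nearest neighbour, compound 2, and its furthest, compound 3, both sit lower by an amount within the scatter, so the three cannot be told apart in this assay. Among the measured compounds shown here, no pair among them differs in only one place, so nothing measured here yet shows how far a single substitution moves this assay.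

Compound 4 `Brc1ccccc1C1=NC(c2ccccc2)CO1` has not been measured. Set against compound 1, the change is bromo in place of ethoxy on an aromatic carbon. For the measured compounds named here, no measured step here covers this swap; the expectation therefore rests on the change itself. For compound 4 a rise beyond the scatter is expected, a step of a number 0.48 log units higher from compound 1 to compound 4 (beyond the scatter). Compound 4 is thus estimated to give 4.7, most likely between 4.3 and 5.1.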

Compound 4, partition coefficient: 3.69
Beside the measured number, compound 4's estimate is 1.01 log units above it; the measured number lies below the stated range.
By their numbers in this assay, from the lowest: compound 4; then compounds 2, 3 and 1 (each within the scatter of the next).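

Until now, no two compounds differing in one place had been measured, so this assay had shown no single-change step. Bromo in place of ethoxy on an aromatic carbon, ortho to a large group, now gives a number 0.53 log units lower from compound 1 to compound 4 (beyond the scatter), so this one change at this position moves the number by more than repeat measurements would. Nothing available here explains why the step runs in this direction or has this size.

As far as these compounds go, whether a chloro, a methoxy or a longer alkoxy chain at the same place would bring the number closer to that of compound 1 or compound 4 remains open. Also unanswered is whether bromo in place of ethoxy would give a similar step on a different core.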